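Taking the chloro off a weak growth inhibitor

The source may report more compounds than this note shows. Statements on the series, on what has been measured and on what is new or still open speak of the compounds shown alone.

Measured in a functional assay on A549 cells (Homo sapiens) for antiproliferative activity, read by spectrophotometry, with a stated time of 2 days; a lower number here means a stronger inhibitor of growth, a higher number a weaker inhibitor of growth:
Compound 1 `Cc1ccc(Nc2ncc(C(F)(F)F)c(N3Cc4cccc(N(C)S(C)(=O)=O)c4C3)n2)c(Cl)c1`: > 30000 nM (a limit)
Compound 2 `CN(c1cccc2c1CN(c1nc(Nc3cc(C(F)(F)F)cc(C(F)(F)F)c3)ncc1C(F)(F)F)C2)S(C)(=O)=O`: > 30000 nM (a limit)
Compound 3 `CN(c1cccc2c1CN(c1nc(Nc3ccc(Cl)c(C(F)(F)F)c3)ncc1C(F)(F)F)C2)S(C)(=O)=O`: 15200 nM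

The entries for compound 1 and compound 2 are limits of the assay, not numbers. Compound 3, at 15200 nM, is the only one of the three with an actual number, so there is little to compare it with. The rest of the series is the limit of > 30000 nM in this assay, at which 2 of the 3 values shown sit.

The next compound is compound 4 `CN(c1cccc2c1CN(c1nc(Nc3cccc(C(F)(F)F)c3)ncc1C(F)(F)F)C2)S(C)(=O)=O`, which has hydrogen in place of chloro on an aromatic carbon. The 4-chloro-3-(trifluoromethyl)phenyl group thus becomes 3-(trifluoromethyl)phenyl.

Going by the values given here, no measured step makes this exact change. The nearest evidence is an at least 1.9-fold lower number from compound 1 to compound 3 (0.29 log units; that floor lies within the scatter). That step alters the same group but swaps more than the chloro, and its size is only a floor, so it offers weak guidance. In this assay, a step within the scatter is therefore the likeliest outcome, with a slight lean towards a higher number, and a limit rather than a number is quite possible.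

For compound 4 the estimated value is 22000 nM, with an expected range from 10000 nM to 40000 nM. The expected change is a 1.4-fold higher number from compound 3 to compound 4 (0.16 log units; within the scatter).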

Compound 4, concentration for 50% growth inhibition: > 30000 nM
Compound 4 was reported as a limit; the forecaster's own chance of this, stated with the estimate: 45%; at least 1.3-fold (0.13 log units) between middle value and limit.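

Compound 3 and compound 4 differ only in chloro against hydrogen on the aromatic carbon ortho to a trifluoromethyl group, so in this assay this pair isolates that single change, which the earlier step between two differently substituted phenyl groups could not do: an at least 1.9-fold higher number from compound 3 to compound 4 (0.29 log units; that floor lies within the scatter). As far as these compounds go, compound 4 stands at a limit, not a number, so the true size of this step is unknown and it may be larger than that floor. The pair does show that replacing the chloro with hydrogen at this position brings no gain in growth inhibition, and compound 3 remains the only compound with an actual number, while the other entries share one ceiling: the limit of > 30000 nM in this assay, at which 3 of the 4 values shown sit.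

The steps from compound 1 and from compound 2 to compound 4 cannot be read: both ends of each are limits, which leaves the contribution of the other groups on that phenyl ring unknown. From the compounds shown here alone, it also remains open whether a different group in place of the chloro, such as bromo, methoxy or a nitrile, would give a lower number than compound 3 does.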